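Phenyl in place of benzoyl in the series

The compounds below may be only part of what the source reports. "The series", "measured", "known", "first", "only" and "open" are said of these compounds alone.

In a functional assay on V79-379A cells (Cricetulus griseus) for cytotoxicity, read by MTT assay, in the presence of a further agent that is not named here (a higher number here means a weaker inhibitor, a lower number a stronger inhibitor), compound 2 `COC1=CC(=O)c2c(c(COC(=O)c3ccccc3)c(C)n2C)C1=O` gives 16000 nM, within the scatter of compound 1 `COC1=CC(=O)c2c(c(COC(=O)c3ccc(F)cc3)c(C)n2C)C1=O` at 27000 nM, while compound 3 `COC1=CC(=O)c2c(c(COC(=O)c3ccccc3)c(C3CC3)n2C)C1=O` gives 198000 nM. Compound 4 `COC1=CC(=O)c2c(c(COc3ccccc3)c(C)n2C)C1=O` differs from compound 2 by phenyl in place of benzoyl on an oxygen on a saturated carbon. Among the compounds with values here, no measured step covers this change. The closest evidence is a 1.7-fold lower number from compound 1 to compound 2 (0.23 log units; within the scatter), made on the aromatic ring of the benzoyl group. The large 12-fold higher number from compound 2 to compound 3 (1.09 log units; beyond the scatter) lies at another place, cyclopropyl in place of methyl. No step beyond the scatter is therefore expected, in either direction, though with little support. The expected step is a 1.3-fold higher number from compound 2 to compound 4 (0.10 log units; within the scatter). For compound 4 the estimated value is 20000 nM, with an expected range of 6000 nM to 70000 nM.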

Compound 4, half-maximal inhibitory concentration: 12000 nM
Beside the measured number, compound 4's estimate is 1.7-fold (0.22 log units) above it; measured number inside the range.
By their numbers in this assay, from the lowest: compounds 4, 2 and 1 (each within the scatter of the next, the first and the last beyond it); then compound 3.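

In this assay, phenyl in place of benzoyl on an oxygen on a saturated carbon gives a 1.3-fold lower number from compound 2 to compound 4 (0.12 log units; within the scatter). The step removes a double bond outside aromatic rings and a hydrogen-bond acceptor, along with two heavy atoms, yet the number stays within the scatter, so neither is needed at this place for this read-out. No measurement on hand gives a cause for this result. Open, as far as these compounds go, is how a longer chain, an amine or a carboxylic acid in place of phenyl on that oxygen would read in this assay.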